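The source may hold more compounds than are shown below. What is called first, only, known or untested is meant among the compounds shown, and "the series" means these compounds.

Measured in an ADME assay on the whole organism for pharmacokinetics, with Rattus norvegicus as the target, at a dose of 5 mg/kg by the oral route; a lower number here means less compound in the circulation, a higher number more compound in the circulation at the dose given:
- compound 1 `Cc1nc(-c2nc[nH]n2)ccc1-c1cnc2c(n1)N(CC1CCOCC1)C(=O)CN2`: 230 nM
- compound 2 `COCCN1C(=O)CNc2ncc(-c3ccc(-c4nc[nH]n4)nc3C)nc21`: 1960 nM
- compound 3 `CO[C@H]1CC[C@H](N2C(=O)CNc3ncc(-c4ccc(-c5nc[nH]n5)nc4C)nc32)CC1`: 840 nM

Compound 3 holds the second highest of these three numbers, as shown by a 2.3-fold lower number from compound 2 to compound 3 (0.37 log units; beyond the scatter) and a 3.7-fold higher number from compound 1 to compound 3 (0.56 log units; beyond the scatter). The next compound, compound 4 `Cc1nc(-c2nc[nH]n2)ccc1-c1cnc2c(n1)N(CCC1CCOCC1)C(=O)CN2`, has the same atoms as compound 3, joined differently: 2-(oxan-4-yl)ethyl in place of 4-methoxycyclohexyl on an amide-type nitrogen in a ring. Going by the values given here, no measured step makes this exact change. The closest evidence is the step between compound 1 and compound 3, since the 2-(oxan-4-yl)ethyl of compound 4 resembles the (oxan-4-yl)methyl of compound 1. That comparison points to a lower number, though the two groups are not the same. Compound 2 adds caution, with an 8.5-fold higher number from compound 1 to compound 2 (0.93 log units; beyond the scatter) showing that another group on this nitrogen can give a much higher number. A step somewhat smaller than the full gap between compound 1 and compound 3 is therefore expected. The expected step is a 2.4-fold lower number from compound 3 to compound 4 (0.38 log units; beyond the scatter). For compound 4 the estimated value is 350 nM, with an expected range of 120 nM to 1000 nM.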

Compound 4, maximal plasma concentration: 590 nM
Compound 4: the middle estimate sits 1.7-fold (0.23 log units) below what was measured; low and high end bracket the measured number.
By their numbers in this assay, from the lowest: compound 1; then compounds 4 and 3 (each within the scatter of the next); then compound 2.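

In this assay, rearranging the same atoms from 4-methoxycyclohexyl to 2-(oxan-4-yl)ethyl on the amide-type nitrogen gives a 1.4-fold lower number from compound 3 to compound 4 (0.15 log units; within the scatter) and so leaves the two groups indistinguishable in this measurement. Within the oxane-bearing groups, the chain length at this nitrogen does register: going from (oxan-4-yl)methyl to 2-(oxan-4-yl)ethyl gives a 2.6-fold higher number from compound 1 to compound 4 (0.41 log units; beyond the scatter) and places the low number of compound 1 apart from its longer-chain partner. Oxan-4-yl in place of methoxy on the chain gives a 3.3-fold lower number from compound 2 to compound 4 (0.52 log units; beyond the scatter) and shows that the 2-methoxyethyl group retains the highest number of the four compounds.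

As far as these compounds go, whether a longer chain ending in oxan-4-yl, or a piperidine ring in its place, would continue this trend remains open. Nothing shown here offers an explanation for these differences.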